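Working notes: bromo in place of methyl on compound 1

The source may report more compounds than this note shows. Statements on the series, on what has been measured and on what is new or still open speak of the compounds shown alone.

Measured so far in a functional assay on BGC-823 cells (Homo sapiens) for inhibition, read by MTT assay, with a stated time of 72 h; on this read-out lower numbers stand for stronger inhibition and higher numbers for weaker inhibition:
- compound 1 `Cc1ccc(N2CCCC2)c(C(=O)Nc2ccc(CNC(=O)OCc3cccnc3)cc2)c1`: > 100000 nM
- compound 2 `Cc1ccc(C(=O)Nc2ccc(CNC(=O)OCc3cccnc3)cc2)c(N2CCCC2)c1`: > 100000 nM

Both entries are limits of the assay and not numbers. Compound 1 stands at such a limit, and compound 2 shares it: the limit of > 100000 nM in this assay, at which 2 of the 2 values shown sit. Going by the values given here, the series therefore shows no measured step and no numerical value so far.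

Compound 3 `O=C(NCc1ccc(NC(=O)c2cc(Br)ccc2N2CCCC2)cc1)OCc1cccnc1` differs from compound 1 by one change bromo in place of methyl on an aromatic carbon, para to a pyrrolidin-1-yl group. Among the compounds with values here, no measured step gives a size for this change in this assay. The expected step of a number no higher from compound 1 to compound 3 (the limit leaves the size open) is none beyond the scatter, in neither direction, and this expectation rests only on compound 1 reading > 100000 nM. Compound 3 is estimated at 100000 nM, with an expected range from 20000 nM to 300000 nM.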

Compound 3, half-maximal inhibitory concentration: > 100000 nM
Compound 3 was reported as a limit (the forecaster's own chance of this, stated with the estimate: 65%); the middle value sits exactly at the limit.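

No step from compound 1 to compound 3 can be read, since both entries are limits and not numbers: the limit of > 100000 nM in this assay, at which 3 of the 3 values shown sit.

The compounds shown leave open whether bromo in place of methyl changes inhibition at all, and whether any member of the series reaches a measured number in this assay.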